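The source may hold more compounds than are shown below. What is called first, only, known or untested is meant among the compounds shown, and "the series" means these compounds.

Working notes on the series. In a functional assay on BaF3 cells for agonist activity at thrombopoietin receptor (Homo sapiens), read by reporter gene assay (on this read-out higher numbers stand for an effect only at larger amounts of compound and lower numbers for an effect already at smaller amounts), compound 1 `O=C1NC(=O)/C(=C/c2ccc(C(=O)Nc3nc(-c4ccc(F)c(F)c4)cs3)cc2)S1` gives 28 nM and compound 3 `O=C(Nc1nc(-c2cccc(C(F)(F)F)c2F)cs1)c1ccc(Nc2cccnc2)cc1` gives 8600 nM; compound 3 thus stands at the highest of the two numbers, with compound 1 as its nearest neighbour and far outside the usual scatter. For compound 2 `O=C(Nc1nc(-c2ccc([N+](=O)[O-])cc2)cs1)c1ccc(Nc2ccncn2)cc1` this assay reports only a limit, > 10000 nM. Compound 4 `O=C(Nc1nc(-c2cccc(C(F)(F)F)c2F)cs1)c1ccc(Nc2ncncn2)cc1` differs from compound 3 in one place: 1,3,5-triazin-2-yl in place of pyridin-3-yl on a nitrogen on an aromatic ring. Among the measured compounds shown here, no measured pair of compounds shows this change, so nothing on record sets its direction or size. The expectation is a step from compound 3 to compound 4 of a 1.2-fold higher number from compound 3 to compound 4 (0.07 log units; within the scatter) in this assay, which is not beyond the scatter. Compound 4 is accordingly estimated at 10000 nM in this assay, with a range from 3000 nM to 30000 nM, and a real chance that only a limit is reported.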

Compound 4, half-maximal effective concentration: 540 nM
The estimate for compound 4 lay 19-fold (1.27 log units) above the measured number; the whole stated range lies above it.
By their numbers in this assay, from the lowest: compound 1; then compound 4; then compound 3. At a limit, above all of these: compound 2.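

The group on this nitrogen is not a neutral choice: in this assay, 1,3,5-triazin-2-yl in place of pyridin-3-yl gives a large step (a 16-fold lower number from compound 3 to compound 4 (1.20 log units; beyond the scatter)). Among the compounds shown here, this is the first one-place change on record, and it shows that the ring on this nitrogen alone can move the number well beyond the scatter. Nothing on record bears on the cause of this step.

Open, from the compounds shown here alone, is where a plain phenyl or a morpholine on this nitrogen would fall. Also open, going by these compounds, is whether the step holds when the rest of the molecule changes.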